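The source may report more compounds than this note shows. Statements on the series, on what has been measured and on what is new or still open speak of the compounds shown alone.

Compound 3, `Cc1cn([C@@H]2O[C@H](CO[Si](C)(C)C(C)(C)C)[C@@]3(OS(=O)(=O)C=C3NCCC(N)=O)[C@H]2O[Si](C)(C)C(C)(C)C)c(=O)n(C)c1=O`, is tested in a functional assay on HEL cells (Homo sapiens) (on this read-out lower numbers stand for higher toxicity in this test and higher numbers for lower toxicity in this test), where compound 3 gives 14800 nM. Its two neighbours are compound 1, `CCNC(=O)NC1=CS(=O)(=O)O[C@@]12[C@@H](CO[Si](C)(C)C(C)(C)C)O[C@@H](n1cc(C)c(=O)n(C)c1=O)[C@@H]2O[Si](C)(C)C(C)(C)C`, which in this assay gives 10000 nM, and compound 2, `Cc1cn([C@@H]2O[C@H](CO[Si](C)(C)C(C)(C)C)[C@@]3(OS(=O)(=O)C=C3NC(=O)c3ccccc3)[C@H]2O[Si](C)(C)C(C)(C)C)c(=O)n(C)c1=O`, which in this assay gives 9700 nM. The three numbers sit together: a 1.5-fold higher number from compound 1 to compound 3 (0.17 log units; within the scatter), a 1.5-fold higher number from compound 2 to compound 3 (0.18 log units; within the scatter) and a 1.0-fold lower number from compound 1 to compound 2 (0.01 log units; within the scatter). Compound 4, `Cc1cn([C@@H]2O[C@H](CO[Si](C)(C)C(C)(C)C)[C@@]3(OS(=O)(=O)C=C3NCCC(=O)O)[C@H]2O[Si](C)(C)C(C)(C)C)c(=O)n(C)c1=O`, differs from compound 3 only in one place: hydroxy in place of amino on a carbonyl carbon. Going by the values given here, no measured step bears directly on this change, since the earlier steps exchange whole substituents on the amine nitrogen or the carbonyl carbon and all stay within the scatter. Compound 4 is therefore expected to give 14000 nM in this assay, with a range of 7000 nM to 28000 nM, which means an expected step of a 1.1-fold lower number from compound 3 to compound 4 (0.02 log units; within the scatter).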

Compound 4, half-maximal cytotoxic concentration: 34000 nM
Estimate against measurement, compound 4: 2.4-fold (0.39 log units) below; measured number outside the range, above it.
By their numbers in this assay, from the lowest: compounds 2, 1 and 3 (each within the scatter of the next); then compound 4.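

In this assay, a change of one heavy atom on the carbonyl carbon, hydroxy in place of amino, moves the number beyond the scatter (a 2.3-fold higher number from compound 3 to compound 4 (0.36 log units; beyond the scatter)). The 2-carboxyethyl group also stands apart from benzoyl (a 3.5-fold higher number from compound 2 to compound 4 (0.54 log units; beyond the scatter)) and ethylcarbamoyl (a 3.4-fold higher number from compound 1 to compound 4 (0.53 log units; beyond the scatter)) on the amine nitrogen, whereas the steps among compound 1, compound 2 and compound 3 all stayed within the scatter. Nothing measured here accounts for this shift. Going by these compounds, whether a methyl ester or a longer chain ending in a carboxylic acid would keep the higher number remains open.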